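A few compounds are considered here, and "the series" means these few. Any claim that something is new, unique, unknown or untested is made for them only; others in the source may bear on it.

Measured so far in a functional assay on NCI-H460 cells (Homo sapiens) for inhibition, read by MTT assay, with a stated time of 72 h; a higher number here means a weaker inhibitor, a lower number a stronger inhibitor:
compound 1 `O=C1Nc2ccccc2/C1=C\C(=O)c1cc(F)cc(F)c1` gives 13300 nM
compound 2 `CC(=O)Nc1cccc(C(=O)/C=C2/C(=O)Nc3ccccc32)c1` gives 12300 nM

Compound 2 and compound 1 sit within the scatter of each other in this assay, so nothing separates the two on the numbers available; compound 2 is simply the starting point for the next step. Among the measured compounds shown here, both compounds share the same core, and the two numbers say only that a change elsewhere on the aryl ketone side has not moved the read-out beyond the noise.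

Compound 3 `CC(C)C(=O)Nc1cccc(C(=O)/C=C2/C(=O)Nc3ccccc32)c1` has not yet been measured. It differs from compound 2 in one place: isopropyl in place of methyl on a carbonyl carbon. The change is a small growth of the acyl chain, with no ring, donor or acceptor added or removed. For the measured compounds named here, no measured pair tracks this position, so there is no step to lean on; the only guide is that the pair compound 1 and compound 2 agrees within scatter, which points to a shallow response of this assay to peripheral edits.

The expectation for compound 3 in this assay is therefore a step from compound 2 of a 1.1-fold lower number from compound 2 to compound 3 (0.05 log units; within the scatter), no larger than the scatter and with no clear direction. Compound 3 is estimated at 11000 nM, in the range 4000 nM to 30000 nM.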

Compound 3, half-maximal inhibitory concentration: 9700 nM
Estimate against measurement, compound 3: 1.1-fold (0.05 log units) above; measured number inside the range.
By their numbers in this assay, from the lowest: compounds 3, 2 and 1 (each within the scatter of the next).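

This position now has its first direct reading: in this assay, isopropyl in place of methyl on a carbonyl carbon whose other neighbour is an amide-type nitrogen gives a 1.3-fold lower number from compound 2 to compound 3 (0.10 log units; within the scatter). The acetamido and (isopropylcarbonyl)amino forms therefore cannot be separated on this read-out, so this swap of acyl groups, with no ring, donor or acceptor entering or leaving, gives no measurable handle on the series. Nothing available explains this flat result or links it to any property of the two groups.

The compounds shown cover only methyl and isopropyl on this carbonyl carbon, so they leave open whether a longer chain, a phenyl ring, an amine or a carboxylic acid in the same place would produce a step beyond the scatter in this assay. They also leave open whether the same flat response holds at other places on the aryl ketone side, since a single step at a single position cannot establish a trend for the series.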